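This account rests on a few compounds, and the source may have more. Where it says the series, first, only, none or still open, it means among the compounds named here.

In a functional assay on HT-29 cells (Homo sapiens) for inhibition, read by sulforhodamine B assay, with a stated time of 48 h (on this read-out lower numbers stand for stronger inhibition of growth and higher numbers for weaker inhibition of growth), compound 3 (`O=C(CCl)NC(=O)Nc1ccc(-c2ccccc2)cc1`) gives 2300 nM, within the scatter of compound 2 (`Cc1ccc(NC2=NCCO2)cc1C`) at 2700 nM, while compound 1 (`Cc1ccc(NC2=NCCO2)cc1`) gives the higher number of 13000 nM. Compound 4 (`O=C(CCl)NC(=O)Nc1ccc(Oc2ccccc2)cc1`) carries phenoxy in place of phenyl on an aromatic carbon. Within the data shown here, the only measured step, a 4.8-fold lower number from compound 1 to compound 2 (0.68 log units; beyond the scatter), is a methyl change on another core, so it bears only weakly on this exchange. Among the measured compounds shown here, no measured step covers phenoxy in place of phenyl. No change beyond the scatter is therefore expected in this assay, and no direction can be assigned. The estimated step is a 1.1-fold higher number from compound 3 to compound 4 (0.04 log units; within the scatter). Compound 4 is expected at 2500 nM, with an estimated range from 900 nM to 7000 nM.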

Compound 4, concentration for 50% growth inhibition: 3600 nM
The estimate for compound 4 lay 1.4-fold (0.16 log units) below the measured number; the measured number falls inside the stated range.
By their numbers in this assay, from the lowest: compounds 3, 2 and 4 (each within the scatter of the next); then compound 1.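

Notes on the series: at this position, on an aromatic carbon para to a group of 8 heavy atoms, phenoxy in place of phenyl gives a 1.6-fold higher number from compound 3 to compound 4 (0.19 log units; within the scatter) in this assay and stays within the scatter. The exchange adds one oxygen and one hydrogen-bond acceptor, and the read-out does not separate the two compounds. No evidence on the cause of this result is available.

On these data alone, whether an amine, a carboxylic acid or a longer chain at this position would move the number beyond the scatter stays open. Also open, as far as these compounds go, is whether phenoxy would behave alike on the core of compound 1.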